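Stripping the benzyl group from compound 2

The source may hold more compounds than are shown below. What is called first, only, known or untested is meant among the compounds shown, and "the series" means these compounds.

Compound 2 `CCCCC[Se]c1nc(NCc2ccccc2)c2ccccc2n1` gives 72500 nM in a functional assay on CCRF-CEM cells (Homo sapiens) for cytotoxicity, read by MTT assay, with a stated time of 72 h (on this read-out higher numbers stand for weaker inhibition of growth and lower numbers for stronger inhibition of growth), the lowest of the two numbers seen here, and compound 1 `CCCCC[Se]c1nc(NCc2ccc(SC)cc2)c2ccccc2n1` sits close to it with 83900 nM. Compound 3 `CSc1nc(NCc2ccccc2)c2ccccc2n1` reaches only a limit of the assay in this assay, > 100000 nM. Compound 4 `CCCCC[Se]c1nc(N)c2ccccc2n1` differs from compound 2 by hydrogen in place of benzyl on a nitrogen on an aromatic ring. Neither measured step touches that nitrogen: a 1.2-fold lower number from compound 1 to compound 2 (0.06 log units; within the scatter) trims only the benzyl ring, and an at least 1.3-fold higher number from compound 2 to compound 3 (0.13 log units; that floor lies within the scatter) alters a different group on the shared core, both staying within the scatter. Removing the whole benzyl group is therefore untested. A rise in the number is expected, a 2.1-fold higher number from compound 2 to compound 4 (0.32 log units; beyond the scatter). Compound 4 is expected to give 150000 nM in this assay, between 60000 nM and 400000 nM, quite possibly only as a limit.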

Compound 4, concentration for total growth inhibition: 68000 nM
Compound 4: the middle estimate sits 2.2-fold (0.34 log units) above what was measured; the measured number falls inside the stated range.
By their numbers in this assay, from the lowest: compounds 4, 2 and 1 (each within the scatter of the next). At a limit, above all of these: compound 3.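

Replacing benzyl with hydrogen on this nitrogen gives a 1.1-fold lower number from compound 2 to compound 4 (0.03 log units; within the scatter) in this assay. The earlier compounds shown here changed only the far end of the benzyl ring, whereas here the whole benzyl group gives way to a plain amino group with no change beyond the scatter, so the benzyl group is not needed for this level of growth inhibition. Compound 3 remains the only compound at a limit: the limit of > 100000 nM in this assay, at which 1 of the 4 values shown sits.

Still open, from the compounds shown here alone, is whether a methyl group, an acetyl group or a longer chain on this nitrogen would move the number beyond the scatter.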